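The source may hold more compounds than are shown below. What is called first, only, known or untested is meant among the compounds shown, and "the series" means these compounds.

Measured so far in a functional assay on HEK293 cells for agonist activity at Neuronal acetylcholine receptor; alpha4/beta2 (Homo sapiens), read by FLIPR; on this read-out higher numbers stand for an effect only at larger amounts of compound and lower numbers for an effect already at smaller amounts: compound 1 `c1cncc(N2CC[C@H]3CN[C@H]3C2)c1` gives 71 nM; compound 2 `COc1cc(N2C[C@@H]3CCNC[C@@H]32)cnc1Br` gives 1690 nM.

Compound 2 holds the highest of the two numbers in this assay; its nearest neighbour, compound 1, sits at a lower number, and that gap lies beyond the scatter. Compound 3 `COc1cc(N2C[C@H]3CCNC[C@H]32)cnc1Br` is the next member: the two compounds have the same atoms and bonds and differ only in configuration as drawn: 2 of 2 stereo elements differ (all stereocentres are inverted: mirror images); a stereocentre at a saturated ring carbon is drawn S in compound 2 and R in compound 3; a stereocentre at a saturated ring carbon is drawn R in compound 2 and S in compound 3. Among the compounds with values here, no measured pair shows what such a full inversion does, so neither size nor direction of the step in this assay can be read from the data; a step beyond the scatter either way is plausible. Compound 3 is estimated at 1000 nM, within 100 nM to 10000 nM. The expected step from compound 2 to compound 3 is a 1.7-fold lower number from compound 2 to compound 3 (0.23 log units; within the scatter).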

Compound 3, half-maximal effective concentration: 200 nM
Compound 3: the middle estimate sits 5.0-fold (0.70 log units) above what was measured; the range from low to high includes it.
By their numbers in this assay, from the lowest: compound 1; then compound 3; then compound 2.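

In this assay full inversion of both stereocentres gives an 8.5-fold lower number from compound 2 to compound 3 (0.93 log units; beyond the scatter) as the first measured effect of configuration in the series. With atoms and bonds unchanged, the step can be traced to configuration alone: the fact that compounds 2 and 3 differ only in the configuration as drawn. The arrangement drawn in compound 3 thus gives an effect at smaller amounts of compound, though one mirror-image pair sets no rule for other members.

Which of the two stereocentres carries the step stays open. Also open, from the compounds shown here alone, is whether the same preference holds with chlorine or a nitrile replacing the bromine, or an amine replacing the methoxy.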